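A few compounds are considered here, and "the series" means these few. Any claim that something is new, unique, unknown or untested is made for them only; others in the source may bear on it.

In a functional assay on P388 cells (Mus musculus) for cytotoxicity, read by sulforhodamine B assay, with a stated time of 48 h (on this read-out higher numbers stand for an effect only at larger amounts of compound and lower numbers for an effect already at smaller amounts), compound 3 `CCCC[C@H](OC(C)=O)[C@@H](OC(C)=O)[C@H](OC(C)=O)[C@H]1CC=CC(=O)O1` gives 1 ug/mL. Compound 1 `CCCC[C@H](OC(C)=O)[C@@H](O)[C@H](O)[C@@H]1OC(=O)C=C[C@@H]1OC(C)=O` gives 0.5 ug/mL, and these two numbers lie within the usual scatter of each other. Compound 2 `CCCC[C@@H](/C=C\[C@@H]1OC(=O)C[C@@H](OC)[C@@H]1O)OC(C)=O` gives > 5 ug/mL, which is a limit of the assay and not a number. The next compound, compound 4 `CCCC[C@H](OC(C)=O)[C@@H](OC(C)=O)[C@H](OC(C)=O)[C@@H]1OC(=O)C=C[C@@H]1OC(C)=O`, differs from compound 3 by one change, acetoxy in place of hydrogen on a saturated ring carbon. Going by the values given here, no measured pair of compounds shows this change on its own, so the expectation starts from compound 3 at 1 ug/mL. The expected step, a 1.4-fold lower number from compound 3 to compound 4 (0.15 log units; within the scatter), stays within the scatter. For compound 4 the estimated value is 0.7 ug/mL, with an expected range of 0.2 ug/mL to 2.5 ug/mL.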

Compound 4, concentration for half-maximal effect: 0.4 ug/mL
Compound 4: middle estimate off by 1.8-fold (0.24 log units), on the high side; the range from low to high includes it.
By their numbers in this assay, from the lowest: compounds 4, 1 and 3 (each within the scatter of the next, the first and the last beyond it). At a limit, above all of these: compound 2.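

In this assay, going by these compounds alone, putting acetoxy on this saturated ring carbon, two ring bonds from the ring oxygen, gives a 2.5-fold lower number from compound 3 to compound 4 (0.40 log units; beyond the scatter) and is the first measured step for this change. The position therefore accepts acetoxy, and the number goes down modestly rather than up. None of the measurements shown bears on why this step occurs. As far as these compounds go, only hydrogen and acetoxy are compared at this carbon in a single step, so it remains open whether an amine or a longer acyloxy chain there would behave alike.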